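Trimming an Amide: Clearance Expectations in Human Hepatocytes

The source may hold more compounds than are shown below. What is called first, only, known or untested is meant among the compounds shown, and "the series" means these compounds.

Of the compounds shown here, three sharing one core have been measured in an ADME assay on cells (Hepatocyte, Homo sapiens) for metabolic stability; on this read-out higher numbers stand for fast clearance and lower numbers for slow clearance. Compound 2 `CC(C)n1cc(-c2ccnc3[nH]c(C4CCN(CC(=O)N5CCCC5)CC4)cc23)ccc1=O` gives 3.5 uL/min. Compound 1 `CC(C)n1nc(-c2ccnc3[nH]c(C4CCN(CC(=O)N(C)C)CC4)cc23)ccc1=O` gives 2 uL/min, a number that sits within the usual scatter of the value of compound 2, so the two cannot be told apart. Compound 3 `COc1cc(C(=O)N2CCCC2)ccc1-c1ccnc2[nH]c(C3CCNCC3)cc12` gives only a limit of the assay, < 1 uL/min. Compound 4 `CNC(=O)CN1CCC(c2cc3c(-c4ccc(=O)n(C(C)C)c4)ccnc3[nH]2)CC1` is not yet measured and differs from compound 2 in one place: methylamino in place of pyrrolidin-1-yl on a carbonyl carbon. Among the measured compounds shown here, no measured step of this kind exists among the three compounds, so the expectation rests on the narrow range of numbers seen so far: a small step is expected, a 1.6-fold lower number from compound 2 to compound 4 (0.20 log units; within the scatter), within the scatter or toward slower clearance. Compound 4 is thus estimated at 2.2 uL/min in this assay, between 1 uL/min and 5 uL/min.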

Compound 4, intrinsic clearance in a liver preparation (reported as CLH), per the amount of preparation that the assay uses: 1.7 uL/min
For compound 4 the middle estimate is 1.3-fold (0.11 log units) above the measured one; the measured number falls inside the stated range.
By their numbers in this assay, from the lowest: compounds 4, 1 and 2 (each within the scatter of the next, the first and the last beyond it). At a limit, below all of these: compound 3.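

In this assay, methylamino in place of pyrrolidin-1-yl on the carbonyl carbon gives a 2.1-fold lower number from compound 2 to compound 4 (0.31 log units; beyond the scatter), the first single change read at this position. In this pair, losing the ring and gaining the amide hydrogen goes with slower clearance, not faster, though the step is modest. Compound 3 gives only a limit of the read-out, so little room for lower numbers may remain: the limit of < 1 uL/min in this assay, at which 1 of the 4 values shown sits.

As far as these compounds go, how a plain amino group or a morpholine ring on the same carbonyl carbon would read stays open. So does whether this change would give a similar step in another compound.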